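The source may hold more compounds than are shown below. What is called first, only, known or untested is meant among the compounds shown, and "the series" means these compounds.

Measured so far in an assay on CHO-K1 cells for displacement of a labelled ligand from Neuronal acetylcholine receptor; alpha4/beta2 (Homo sapiens), read by scintillation counting; on this read-out higher numbers stand for weaker inhibition and lower numbers for stronger inhibition:
compound 1 `c1cncc(OC[C@]23C[C@H]2CCN3)c1` — 242 nM
compound 2 `Clc1cncc(OC[C@]23C[C@H]2CCN3)c1` — 827 nM
compound 3 `Clc1nccnc1OC[C@@H]1C[C@H]2C[C@H]2N1` — 5110 nM

Compound 1 and compound 2 share a core and differ by one change, (hydrogen in place of chloro on an aromatic carbon). That step, a 3.4-fold lower number from compound 2 to compound 1 (0.53 log units; beyond the scatter), is beyond the scatter and gives the first direction available for removing the chloro. Compound 3 carries a different core, and the difference between the two cores is not broken down here; on this assay compound 3 stands highest of the three, beyond the scatter from both compound 2 and compound 1.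

Compound 4 `c1cnc(OC[C@@H]2C[C@H]3C[C@H]3N2)cn1` has not yet been measured. It differs from compound 3 by hydrogen in place of chloro on an aromatic carbon. Going by the values given here, this is the same kind of change as the one from compound 2 to compound 1, not the same one: in compound 2 the chloro sits on a ring with 1 nitrogen, two atoms from the ring nitrogen, meta to a group of 8 heavy atoms, whereas in compound 3 it sits on a ring with 2 nitrogen, next to the ring nitrogen, ortho to a group of 8 heavy atoms. Among the compounds with values here, only one measured instance of this kind of change exists, so the expectation rests on compound 2 alone and on a 3.4-fold lower number from compound 2 to compound 1 (0.53 log units; beyond the scatter). A step of roughly that size is expected from compound 3 to compound 4, a 2.8-fold lower number from compound 3 to compound 4 (0.45 log units; beyond the scatter), with wide uncertainty because the surroundings of the place differ and compound 3 gives 5110 nM on a core not otherwise sampled. For compound 4 the estimate in this assay is 1800 nM, between 600 nM and 5500 nM.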

Compound 4, inhibition constant: > 10000 nM
Compound 4 was reported as a limit; the forecaster's own chance of this, stated with the estimate: 5%; at least 5.5-fold (0.74 log units) between middle value and limit.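

Hydrogen in place of chloro on an aromatic carbon does not carry from one core to the other with a single direction in this assay: the same change on two cores in this assay, a 3.4-fold lower number (0.53 log units; beyond the scatter) from compound 2 to compound 1 and an at least 1.9-fold higher number (0.29 log units; that floor lies within the scatter) from compound 3 to compound 4, at least 6.6-fold (0.82 log units) apart, beyond the scatter of two such steps. Compound 4 is reported only as a limit of the assay, not as a number: the limit of > 10000 nM in this assay, at which 1 of the 4 values shown sits. Going by these compounds alone, the new step, an at least 1.9-fold higher number from compound 3 to compound 4 (0.29 log units; that floor lies within the scatter), is a floor whose true size stays unknown, and with only one pair on each core, and with the core, the aromatic ring and the place of the chloro all differing between the pairs, the data do not show which of these separates the two outcomes.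

Open, on these data alone, is whether the core of compound 3 would respond to the loss of chloro in the same way on the aromatic ring of compound 2, which would separate the effect of the core from that of the ring. Also open, as far as these compounds go, is how a methyl, a bromo or an amine in place of the chloro would read on either core.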